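Series notes: methylcarbamoyl to methoxycarbonyl

The source may hold more compounds than are shown below. What is called first, only, known or untested is meant among the compounds shown, and "the series" means these compounds.

Measured in a functional assay on HCT-116 cells (Homo sapiens) for inhibition, with a stated time of 72 h; on this read-out lower numbers stand for stronger inhibition and higher numbers for weaker inhibition:
- compound 1 `CNC(=O)C1=C[C@@H]2[C@@H](C(C)C)CC[C@@]3(CO3)[C@H]2C(=O)OC1`: 7100 nM
- compound 2 `CNC(=O)C1=C[C@@H]2[C@@H](C(C)C)CC[C@@](O)(CO)[C@H]2C(=O)OC1`: > 32000 nM (a limit of the assay)

Going by the values given here, compound 1 at 7100 nM holds the only actual number and is the sole numeric reference point. Compound 2 reads > 32000 nM and that reading is a limit, not a number.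

The next compound to be read is compound 3 `COC(=O)C1=C[C@@H]2[C@@H](C(C)C)CC[C@@]3(CO3)[C@H]2C(=O)OC1` which keeps the core of compound 1 and carries methoxy in place of methylamino on a carbonyl carbon. The same difference, cut one bond further out, reads methylcarbamoyl to methoxycarbonyl. Among the compounds with values here, no measured step covers this change, so the expectation rests on compound 1 at 7100 nM alone and stays wide. A moderate step toward stronger inhibition is expected in this assay although a result within the usual scatter would be no surprise. The estimated change is a 2.4-fold lower number from compound 1 to compound 3 (0.37 log units; beyond the scatter) and its direction is the less certain part of this expectation. For compound 3 the estimated value is 3000 nM with an expected range from 800 nM to 12000 nM on this read-out.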

Compound 3, half-maximal inhibitory concentration: 2190 nM
The estimate for compound 3 lay 1.4-fold (0.14 log units) above the measured number; the measured number falls inside the stated range.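

In this assay, going by these compounds alone, the change from methylcarbamoyl to methoxycarbonyl gives a 3.2-fold lower number from compound 1 to compound 3 (0.51 log units; beyond the scatter), the first step that can be read as a number. At this place, on a carbonyl carbon attached to a double-bonded ring carbon, the amide hydrogen of compound 1 is therefore not needed to keep inhibition on this read-out, and methoxy gives a lower number than methylamino on the core of compound 1, though this rests on a single pair. Compound 2 carries a limit rather than a number, so no step involving it can be read: the limit of > 32000 nM in this assay, at which 1 of the 3 values shown sits.

Only methylamino and methoxy are shown on this carbonyl carbon, so it remains open whether the lower number belongs to methoxy itself or simply to the loss of the amide hydrogen, and a dimethylamino group, an ethoxy group or a carboxylic acid at the same place would help separate these readings. On these data alone, it also remains open whether the same change would give a step of similar size on the core of compound 2.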